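Swapping methoxy for nitro to give compound 3

The source may report more compounds than this note shows. Statements on the series, on what has been measured and on what is new or still open speak of the compounds shown alone.

Compound 1 (`Cc1ccc(NC(=O)CCc2cccc3c2B(O)OC3)cc1`) gives (4500 nM)
Compound 2 (`COc1ccc(NC(=O)CCc2cccc3c2B(O)OC3)cc1`) gives (1700 nM)

Both values come from a functional assay on HCT-116 cells (Homo sapiens) for antiproliferative activity, read by MTT assay, with a stated time of 72 h (on this read-out lower numbers stand for stronger inhibition and higher numbers for weaker inhibition), and compound 2 holds the lower of the two numbers. Compound 3 (`O=C(CCc1cccc2c1B(O)OC2)Nc1ccc([N+](=O)[O-])cc1`) differs from compound 2 at one place, with nitro in place of methoxy on an aromatic carbon. Within the data shown here, the only measured step at that place is modest but beyond the scatter (a 2.6-fold lower number from compound 1 to compound 2 (0.42 log units; beyond the scatter)). Among the measured compounds shown here, no nitro compound has been measured, so a step no larger than that one is expected in this assay, more likely toward a higher number. The estimated step is small (a 1.6-fold higher number from compound 2 to compound 3 (0.22 log units; within the scatter)). Compound 3 is expected at 2800 nM (estimated range 900 nM to 8000 nM).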

Compound 3, half-maximal inhibitory concentration: > 100000 nM
Compound 3: no number, only a limit; the forecaster's own chance of this, stated with the estimate: 5%; middle value at least 35-fold (1.55 log units) away from the limit.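

Compound 3 gives no number, only a limit of the assay: the limit of > 100000 nM in this assay, at which 1 of the 3 values shown sits.

Among these compounds, the position para to a large group is thus more sensitive than the modest step between the earlier compounds suggested, with nitro giving an at least 58-fold higher number from compound 2 to compound 3 (1.76 log units; beyond the scatter) and an at least 22-fold higher number from compound 1 to compound 3 (1.34 log units; beyond the scatter). A single change at this place can take the number out of the measured range.

The compounds shown leave open whether an amine or a carboxylic acid at this place would stay close to compound 2 or go the way of compound 3. They also do not tell what about nitro lies behind this step.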